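Sulfur substituent exchange on compound 1

A few compounds are considered here, and "the series" means these few. Any claim that something is new, unique, unknown or untested is made for them only; others in the source may bear on it.

Measured in a functional assay on DU-145 cells (Homo sapiens) for inhibition, read by trypan blue exclusion, with a stated time of 96 h; a lower number here means a stronger inhibitor of growth, a higher number a weaker inhibitor of growth:
- Compound 1 `COc1cc(OC)c(/C=C(/SCc2ccc(Cl)cc2)C(=O)c2ccc(Br)cc2)c(OC)c1`: 1000 nM
- Compound 2 `COc1cc(OC)c(/C=C(/SCc2ccc(Cl)cc2)C(=O)c2ccc([N+](=O)[O-])cc2)c(OC)c1`: > 100000 nM, a limit of the assay

Going by the values given here, compound 1 holds the only actual number in this assay, since the other result is a limit. Compound 3 `COc1cc(OC)c(/C=C(/Sc2ccc(C)cc2)C(=O)c2ccc(Br)cc2)c(OC)c1` carries 4-methylphenyl in place of 4-chlorobenzyl on a sulfur. Among the compounds with values here, the only measured step, an at least 100-fold higher number from compound 1 to compound 2 (2.00 log units; beyond the scatter), is nitro in place of bromo on an aromatic carbon. It leaves the sulfur substituent unchanged, so it sets no direction here, though it argues for a wide range. The expected change is a 1.5-fold higher number from compound 1 to compound 3 (0.18 log units; within the scatter), which is no step beyond the scatter. For compound 3 the estimated value is 1500 nM, with an expected range of 150 nM to 15000 nM.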

Compound 3, concentration for 50% growth inhibition: > 100000 nM
Compound 3 ended at the assay's limit; the forecaster's own chance of this, stated with the estimate: 10%; middle value at least 66-fold (1.82 log units) from the limit.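

Replacing 4-chlorobenzyl with 4-methylphenyl on the sulfur gives an at least 100-fold higher number from compound 1 to compound 3 (2.00 log units; beyond the scatter), so the sulfur substituent, unchanged in the earlier step, also matters for growth inhibition in this series. The value of compound 3 is a limit, so the step gives only a lower bound on the loss: the limit of > 100000 nM in this assay, at which 2 of the 3 values shown sit.

The change swaps benzyl for phenyl and chloro for methyl at once, and the compounds shown do not separate the two. As far as these compounds go, a 4-chlorophenyl or a 4-methylbenzyl on the sulfur would separate them, and a longer chain such as 2-phenylethyl remains open.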